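Trimming one arm from compound 3 in the receptor binding series

This account rests on a few compounds, and the source may have more. Where it says the series, first, only, none or still open, it means among the compounds named here.

Working notes on the set. Compound 1 `O=C(NCCCNC1CCCCC1)c1ccc(C(=O)NCCCNC2CCCCC2)cc1`, compound 2 `O=C(NCCCNC1CCCCC1)c1ccc(CNCCCNC2CCCCC2)cc1` and compound 3 `c1c(CNCCCNC2CCCCC2)cc(CNCCCNC2CCCCC2)cc1CNCCCNC1CCCCC1` have been run in an assay on CHO cells for displacement of a labelled ligand from C-X-C chemokine receptor type 4 (Homo sapiens), with a stated time of 40 min; a higher number here means a weaker inhibitor, a lower number a stronger inhibitor. Compound 1 gives 1700 nM, compound 2 gives 699 nM and compound 3 gives 312 nM. Compound 3 therefore holds the lowest number of the three, with compound 2 nearest and compound 1 furthest, both gaps beyond the scatter. Compound 4 `c1cc(CNCCCNC2CCCCC2)cc(CNCCCNC2CCCCC2)c1` has not yet been measured in this assay. It differs from compound 3 in one place: hydrogen in place of ((3-(cyclohexylamino)propyl)amino)methyl on an aromatic carbon, meta to two ((3-(cyclohexylamino)propyl)amino)methyl groups. For the measured compounds named here, no step between measured compounds matches this change, so the size rests on judgement. Compound 4 is expected to lie between compound 2 and compound 3, and its step from compound 3 is estimated at a 2.2-fold higher number from compound 3 to compound 4 (0.35 log units; beyond the scatter), a modest loss. For compound 4 the estimate is 700 nM, within a range of 250 nM to 2000 nM.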

Compound 4, half-maximal inhibitory concentration: 156 nM
Compound 4: the middle estimate sits 4.5-fold (0.65 log units) above what was measured; measured number below the stated range.
By their numbers in this assay, from the lowest: compounds 4 and 3 (each within the scatter of the next); then compound 2; then compound 1.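

In this assay, hydrogen in place of ((3-(cyclohexylamino)propyl)amino)methyl on an aromatic carbon gives a 2.0-fold lower number from compound 3 to compound 4 (0.30 log units; within the scatter) and so cannot be told apart from no change. At this position, meta to two ((3-(cyclohexylamino)propyl)amino)methyl groups, the full arm with its 12 heavy atoms and its cyclohexyl ring can therefore be absent without a loss beyond the usual scatter. For the compounds shown here, the earlier compounds gave no pair differing at this place, so this is the first direct reading of what the arm contributes, and within this one pair that contribution is not distinguishable from none.

Still open, from the compounds shown here alone, is how a small group on this aromatic carbon, such as an amine or a carboxylic acid, or a longer chain carrying the same cyclohexylamino end, would read against hydrogen. No measurement is available that would explain why this step is so small.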